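A few compounds are considered here, and "the series" means these few. Any claim that something is new, unique, unknown or untested is made for them only; others in the source may bear on it.

Of the compounds shown here, three have so far been measured in an ADME assay on cells (Hepatocyte, Homo sapiens) for metabolic stability; a lower number here means that the compound disappears faster, a higher number that the compound lasts longer.

Compound 1 `O=C(OC1CCC(CN2CCN(c3cc(=O)c4cc(C(F)(F)F)cc([N+](=O)[O-])c4s3)CC2)CC1)c1ccco1` gives 0.075 h.
Compound 2 `CS(=O)(=O)NC1CCC(CN2CCN(c3cc(=O)c4cc(C(F)(F)F)cc([N+](=O)[O-])c4s3)CC2)CC1` gives > 1.55 h, which is a limit of the assay rather than a number.
Compound 3 `O=C(OC1CCC(CN2CCN(c3cc(=O)c4cc(C(F)(F)F)cc([N+](=O)[O-])c4s3)CC2)CC1)c1ccc(F)cc1` gives 0.0983 h.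

Among the two numbers shown, compound 1 stands lowest, with compound 3 nearest: the step of a 1.3-fold higher number from compound 1 to compound 3 (0.12 log units; within the scatter) puts 4-fluorophenyl in place of furan-2-yl on a carbonyl carbon. Compound 4 `O=C(OC1CCC(CN2CCN(c3cc(=O)c4cc(C(F)(F)F)cc([N+](=O)[O-])c4s3)CC2)CC1)c1ccc(C(F)(F)F)cc1` has not been measured. It differs from compound 1 by 4-(trifluoromethyl)phenyl in place of furan-2-yl on a carbonyl carbon.

The step from compound 1 to compound 3 bears on this change most directly, as it also replaced the furan-2-yl on the carbonyl carbon with a six-membered aromatic ring of carbon only, and it stayed within the scatter. The two large steps, an at least 20-fold higher number from compound 1 to compound 2 (1.31 log units; beyond the scatter) and an at least 15-fold lower number from compound 2 to compound 3 (1.19 log units; beyond the scatter), concern methanesulfonamido on a saturated ring carbon, a different part of the molecule. For compound 2 only a limit is known (the limit of > 1.55 h in this assay, at which 1 of the 3 values shown sits).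

In this assay compound 4 is therefore expected to show no step beyond the scatter, a 1.3-fold higher number from compound 1 to compound 4 (0.12 log units; within the scatter). The estimated half-life of compound 4 is 0.1 h, expected to lie between 0.04 h and 0.3 h.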

Compound 4, half-life: 0.117 h
Compound 4: middle estimate off by 1.2-fold (0.07 log units), on the low side, within the range that was stated.
By their numbers in this assay, from the lowest: compounds 1, 3 and 4 (each within the scatter of the next). At a limit, above all of these: compound 2.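

In this assay, placing 4-(trifluoromethyl)phenyl on the carbonyl carbon instead of furan-2-yl still gives a small step (a 1.6-fold higher number from compound 1 to compound 4 (0.19 log units; within the scatter)), so a second six-membered aromatic ring of carbon only behaves like the first. Trifluoromethyl in place of fluoro on an aromatic carbon also leaves the half-life where it was (a 1.2-fold higher number from compound 3 to compound 4 (0.08 log units; within the scatter)), so these two groups cannot be told apart here, and compounds 1, 3 and 4 now read as one short-lived set whatever aromatic ring sits on that carbonyl carbon. Nothing shown here gives a measured reason why these three half-lives stay together.

All the groups shown on that carbonyl carbon are aromatic rings, so it remains open whether a saturated cyclohexyl ring, a plain alkyl chain or a phenyl ring carrying a carboxylic acid or an amine would read the same. Also open is what an amide in place of the ester oxygen would give: the only other group shown on that saturated ring carbon is the methanesulfonamido of compound 2, whose > 1.55 h is a limit of the assay and not a number.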